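Changing the Aryl Group on the Amide-Type Nitrogen

This account rests on a few compounds, and the source may have more. Where it says the series, first, only, none or still open, it means among the compounds named here.

Compound 2 `COc1cc(-c2nn(-c3cccc(NC(=O)Nc4ccc(Cl)c(Cl)c4)c3)cc2-c2ccncc2)ccc1Cl` was tested in a functional assay on RPMI-8226 cells (Homo sapiens) for inhibition, read by sulforhodamine B assay, with a stated time of 48 h (a higher number here means a weaker inhibitor of growth, a lower number a stronger inhibitor of growth), and gave 3260 nM. On the numbers shown, compound 2 holds the only real value, since the other result is a limit. Compound 1 `O=C(Nc1cccc(-n2cc(-c3ccncc3)c(-c3ccc(Cl)c(O)c3)n2)c1)Nc1cccc(C(F)(F)F)c1` reached only the limit of the assay, reported as > 32500 nM. This is described by the limit of > 32500 nM in this assay, at which 1 of the 2 values shown sits. Compound 3 `COc1cc(-c2nn(-c3cccc(NC(=O)Nc4cccc(C(F)(F)F)c4)c3)cc2-c2ccncc2)ccc1Cl` has not been measured yet. It differs from compound 2 in one place: 3-(trifluoromethyl)phenyl in place of 3,4-dichlorophenyl on an amide-type nitrogen. For the measured compounds named here, no step between two measured compounds covers this exact change, and compound 1, which also carries the trifluoromethyl group, differs from compound 2 in a second place as well, so its limit cannot be read as a clean guide. A moderate loss of growth inhibition is expected, beyond the usual scatter, from compound 2 to compound 3, a 2.5-fold higher number from compound 2 to compound 3 (0.39 log units; beyond the scatter). Compound 3 is therefore estimated at 8000 nM, within a range of 2500 nM to 32500 nM.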

Compound 3, concentration for total growth inhibition: 3120 nM
Compound 3: the middle estimate sits 2.6-fold (0.41 log units) above what was measured; the measured number falls inside the stated range.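

On the amide-type nitrogen, 3-(trifluoromethyl)phenyl and 3,4-dichlorophenyl cannot be told apart in this assay: the swap gives a 1.0-fold lower number from compound 2 to compound 3 (0.02 log units; within the scatter). Compound 3 also offers a one-place comparison with compound 1, as both carry the trifluoromethyl group, and methyl in place of hydrogen on an oxygen on an aromatic ring gives an at least 10-fold lower number from compound 1 to compound 3 (1.01 log units; beyond the scatter). The result for compound 1 is a limit and not a number, so this step has no exact size: the limit of > 32500 nM in this assay, at which 1 of the 3 values shown sits.

Going by these compounds, only these two aryl groups are compared on that nitrogen, so it remains open how a phenyl carrying a nitrile or an amine, or a longer alkyl chain in place of the aryl group, would compare. Also open, on these data alone, is whether an ethyl group on that oxygen would match methyl.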